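The compounds below may be only part of what the source reports. "The series", "measured", "known", "first", "only" and "open" are said of these compounds alone.

In an ADME assay on microsomes from liver (Homo sapiens) for metabolic stability, read by LC-MS, with NADPH named in the record, with a stated time of 60 min, tested at 1 uM, in the absence of a further agent (a higher number here means that more of the compound is left, a lower number that less of the compound is left), compound 1 `COc1ccc(-c2scc3c(N4CC[C@@H](NC(C)=O)C4)nc(C)nc23)cc1OC` gives > 95%, which is a limit of the assay and not an exact number. Compound 2 `CC(=O)N[C@@H]1CCN(c2cc(C)nn3c(-c4ccccc4)c(C)nc23)C1` gives > 95%, which is also a limit. The measurements so far therefore come down to the limit of > 95% in this assay, at which 2 of the 2 values shown sit, and compound 2 has no exact value of its own.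

Compound 3 `COc1cc(-c2c(C)nc3c(N4CC[C@@H](NC(C)=O)C4)cc(C)nn23)ccc1F` keeps the core of compound 2 but carries 4-fluoro-3-methoxyphenyl in place of phenyl on an aromatic carbon. Within the data shown here, no measured pair of compounds shows what a change of this kind does. The expectation therefore rests on the limit of compound 2 at > 95%. A small downward step is expected in this assay, estimated as a number at least 3 percentage points lower from compound 2 to compound 3 (that floor lies within the scatter), and it may stay within the usual scatter. For compound 3 the expected value is 92%, with an estimated range from 75% to 100%.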

Compound 3, percent of the compound remaining: > 95%
Compound 3: a limit, no number (the forecaster's own chance of this, stated with the estimate: 45%); middle value at least 3 percentage points away from the limit.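

Compound 2 and compound 3 both sit at a limit of this assay, so no step can be read for 4-fluoro-3-methoxyphenyl in place of phenyl: the limit of > 95% in this assay, at which 3 of the 3 values shown sit.

The compounds shown leave open whether this change alters how much compound remains, and what would lower that amount.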